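Porcupine series: moving the pyridine nitrogen in compound 1

The compounds below may be only part of what the source reports. "The series", "measured", "known", "first", "only" and "open" are said of these compounds alone.

Measured compounds:
compound 1 `O=C(CSc1nc2c(c(=O)n1-c1ccccc1)SCC2)Nc1ccc(-c2ccccn2)cc1` 4 nM
compound 2 `COc1ccc(-n2nc(C(=O)NCC(=O)Nc3nc4ccc(C)cc4s3)c3ccccc3c2=O)cc1` 25 nM
compound 3 `O=C(CNC(=O)c1nn(-c2ccccc2)c(=O)c2ccccc12)Nc1nc2ccc([N+](=O)[O-])cc2s1` 240 nM

In an assay on L cells for inhibition of Protein-serine O-palmitoleoyltransferase porcupine (Mus musculus), read by reporter gene assay, with a stated time of 24 h (a lower number here means that less compound is needed, a higher number that more compound is needed for the effect), compound 1 gives 4 nM, the lowest of the three numbers; compound 2 gives 25 nM and compound 3 gives 240 nM, both separated from compound 1 by more than the usual scatter. Compounds 2 and 3 share a different scaffold from compound 1, so no single-point comparison within this set is available.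

Compound 4 `O=C(CSc1nc2c(c(=O)n1-c1ccccc1)SCC2)Nc1ccc(-c2ccncc2)cc1` keeps the core of compound 1 and differs in one place: pyridin-4-yl in place of pyridin-2-yl on an aromatic carbon. Going by the values given here, no measured pair in this set isolates this change, so the expected step rests on the general experience that relocating a ring nitrogen within a biaryl usually shifts potency by a modest amount in either direction. For compound 4 a small loss relative to compound 1 is expected, with the step from compound 1 to compound 4 estimated at a 2.5-fold higher number from compound 1 to compound 4 (0.40 log units; beyond the scatter). Compound 4 is thus expected to give about 10 nM in this assay, within a range of 2 nM to 60 nM.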

Compound 4, half-maximal effective concentration: 3 nM
Estimate against measurement, compound 4: 3.3-fold (0.52 log units) above; the range from low to high includes it.
By their numbers in this assay, from the lowest: compounds 4 and 1 (each within the scatter of the next); then compound 2; then compound 3.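

In this assay, going by these compounds alone, the exchange of pyridin-2-yl for pyridin-4-yl gives a 1.3-fold lower number from compound 1 to compound 4 (0.12 log units; within the scatter) and so stays within the scatter, the first single-place comparison. With the same atoms joined differently, the location of the ring nitrogen on this group, which sits on an aromatic carbon para to a large group, leaves the read-out indistinguishable between these two compounds. Nothing measured here explains why the two groups read alike.

Open, going by these compounds, is whether pyridin-3-yl, or a plain phenyl with no ring nitrogen, would read the same as these two pyridines, so the need for the nitrogen itself stays undefined. Also open, on these data alone, is how far a carboxylic acid, an amine or a longer chain on the same aromatic carbon would move the number in this assay on the core of compound 1.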